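Bulkier Group on the Fused Core of Compound 3

A few compounds are considered here, and "the series" means these few. Any claim that something is new, unique, unknown or untested is made for them only; others in the source may bear on it.

Compound 3 `CS(=O)(=O)N1CCN(CC(O)CN2CCC(CNC(=O)c3cccc4[nH]c(C5CC5)nc34)CC2)CC1` shows the lowest of the three numbers in a functional assay for agonist activity at 5-hydroxytryptamine receptor 4 (Homo sapiens), read by cAMP accumulation (a lower number here means that less compound is needed, a higher number that more compound is needed for the effect), where compound 3 gives 0.631 nM, though its nearest neighbour lies within the scatter: compound 2 `CCc1nc2c(C(=O)NCC3CCN(CC(O)CN4CCN(S(C)(=O)=O)CC4)CC3)cccc2[nH]1` gives 1 nM in this assay, and the step of a 1.6-fold lower number from compound 2 to compound 3 (0.20 log units; within the scatter) is small. Compound 1 `CS(=O)(=O)N1CCN(CC(O)CN2CCC(CNC(=O)c3cccc4[nH]cnc34)CC2)CC1`, which carries hydrogen at the same place, gives 10 nM in this assay, so that the step of a 16-fold lower number from compound 1 to compound 3 (1.20 log units; beyond the scatter) is large.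

Compound 4 `CC(C)(C)c1nc2c(C(=O)NCC3CCN(CC(O)CN4CCN(S(C)(=O)=O)CC4)CC3)cccc2[nH]1` differs from compound 3 by tert-butyl in place of cyclopropyl on an aromatic carbon. Among the compounds with values here, the steps that bear on this change are a 10-fold lower number from compound 1 to compound 2 (1.00 log units; beyond the scatter) and a 16-fold lower number from compound 1 to compound 3 (1.20 log units; beyond the scatter), both showing that a carbon group in place of the hydrogen lowers the number, while a 1.6-fold lower number from compound 2 to compound 3 (0.20 log units; within the scatter) shows that exchanging one such group for another changed nothing beyond the scatter. Tert-butyl is a further group of this kind, so no step beyond the scatter is expected. Compound 4 is therefore expected to give 1 nM in this assay, within a range from 0.3 nM to 3.5 nM. This estimate means a step of a 1.6-fold higher number from compound 3 to compound 4 (0.20 log units; within the scatter).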

Compound 4, half-maximal effective concentration: 3.16 nM
The estimate for compound 4 lay 3.2-fold (0.50 log units) below the measured number; low and high end bracket the measured number.
By their numbers in this assay, from the lowest: compounds 3 and 2 (each within the scatter of the next); then compound 4; then compound 1.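

Tert-butyl is the first carbon group at this place to separate from the others in this assay, with a 5.0-fold higher number from compound 3 to compound 4 (0.70 log units; beyond the scatter) and a 3.2-fold higher number from compound 2 to compound 4 (0.50 log units; beyond the scatter), so the earlier agreement of ethyl and cyclopropyl does not extend to every carbon group here. Tert-butyl still keeps part of the advantage over hydrogen, with a 3.2-fold lower number from compound 1 to compound 4 (0.50 log units; beyond the scatter), which places compound 4 in the middle of the series. No supporting evidence is available to explain this difference.

Because tert-butyl differs from cyclopropyl both in having one more carbon and in lacking a ring, the compounds shown do not separate these two changes, and isopropyl or cyclobutyl at this place remains to be compared. From the compounds shown here alone, whether an amine or a phenyl ring would be tolerated here also remains open.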